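Shifting the methoxy group on compound 3

The compounds below may be only part of what the source reports. "The series", "measured", "known", "first", "only" and "open" are said of these compounds alone.

Compound 1 `Cc1ccccc1-c1cc(C)c(Oc2cc(N)nc(Nc3ccc(C#N)cc3)n2)c(C)c1` gives 25600 nM
Compound 2 `Cc1ccc(-c2cc(C)c(Oc3cc(N)nc(Nc4ccc(C#N)cc4)n3)c(C)c2)cc1` gives 10000 nM
Compound 3 `COc1ccccc1-c1cc(C)c(Oc2cc(N)nc(Nc3ccc(C#N)cc3)n2)c(C)c1` gives 21800 nM

All three values come from a toxicity assay on MT4 cells (Homo sapiens) for cytotoxicity, read by MTT assay (on this read-out higher numbers stand for lower toxicity in this test and lower numbers for higher toxicity in this test), and the compounds share one core. Compound 3 stands level with one neighbour and apart from the other: the numbers show a 1.2-fold lower number from compound 1 to compound 3 (0.07 log units; within the scatter) and also a 2.2-fold higher number from compound 2 to compound 3 (0.34 log units; beyond the scatter) in the same set.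

Compound 4 `COc1cccc(-c2cc(C)c(Oc3cc(N)nc(Nc4ccc(C#N)cc4)n3)c(C)c2)c1` has the same atoms joined differently, with 3-methoxyphenyl in place of 2-methoxyphenyl on an aromatic carbon. Going by the values given here, no measured step moves a methoxy group. The closest parallel is 4-methylphenyl in place of 2-methylphenyl, which gave a 2.6-fold lower number from compound 1 to compound 2 (0.41 log units; beyond the scatter) as a modest change. That step involves a different group and a different position, so only a small drop, probably inside the usual scatter, is expected in this assay for this change. The estimated step is a 1.5-fold lower number from compound 3 to compound 4 (0.16 log units; within the scatter) on this reasoning. For compound 4 an estimated 15000 nM is expected, with a likely range of 7000 nM to 30000 nM around it.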

Compound 4, half-maximal cytotoxic concentration: 19300 nM
Compound 4: middle estimate off by 1.3-fold (0.11 log units), on the low side, and the stated range covers the measured number.
By their numbers in this assay, from the lowest: compounds 2, 4, 3 and 1 (each within the scatter of the next, the first and the last beyond it).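

Moving the methoxy group from 2-methoxyphenyl to 3-methoxyphenyl leaves the reading in this assay unchanged within the scatter, with a 1.1-fold lower number from compound 3 to compound 4 (0.05 log units; within the scatter) as the step, so the first move of this group within its phenyl ring shows no clear effect. Compound 4 also lies within the scatter of both methyl-bearing compounds, with a 1.3-fold lower number from compound 1 to compound 4 (0.12 log units; within the scatter) on one side and a 1.9-fold higher number from compound 2 to compound 4 (0.29 log units; within the scatter) on the other. Compound 1 and compound 2 remain beyond the scatter of each other, so compound 4 sits in the gap between them and does not clearly belong with either.

On these data alone, it remains open whether 4-methoxyphenyl, or a phenyl carrying an amine or a carboxylic acid, would move the number beyond the scatter. No supporting evidence is available to explain these readings.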